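The compounds below may be only part of what the source reports. "The series", "measured", "known", "first", "only" and "open" are said of these compounds alone.

Three compounds share the core of compound 1 `COc1ccc(-n2cc(CN3C(=O)C[C@@H]4CC[C@@]3(C)C4(C)C)nn2)cc1`, which in a functional assay on PANC-1 cells (Homo sapiens) for inhibition, read by MTT assay, with a stated time of 24 h (on this read-out lower numbers stand for stronger inhibition and higher numbers for weaker inhibition), gives 330 nM. Compound 2 `CC1(C)[C@H]2CC[C@]1(C)N(Cc1cn(-c3cccc(O)c3)nn1)C(=O)C2` gives 280 nM, and compound 3 `CC1(C)[C@H]2CC[C@]1(C)N(Cc1cn(-c3cccc(F)c3)nn1)C(=O)C2` gives 220 nM. Compound 3 holds the lowest of the three numbers, yet the steps of a 1.5-fold lower number from compound 1 to compound 3 (0.18 log units; within the scatter) and a 1.3-fold lower number from compound 2 to compound 3 (0.10 log units; within the scatter) both lie within the scatter, as does a 1.2-fold lower number from compound 1 to compound 2 (0.07 log units; within the scatter). Compound 4 `CC1(C)[C@H]2CC[C@]1(C)N(Cc1cn(-c3ccccc3F)nn1)C(=O)C2` differs from compound 3 by 2-fluorophenyl in place of 3-fluorophenyl on an aromatic nitrogen, the two having the same atoms joined differently. Each measured exchange of the group on the aromatic nitrogen has given a step within the scatter in this assay, so nothing beyond the scatter is expected for compound 4 either. Compound 4 is therefore estimated at 260 nM, in the range 130 nM to 520 nM. For compound 4 the expected step is a 1.2-fold higher number from compound 3 to compound 4 (0.07 log units; within the scatter).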

Compound 4, half-maximal inhibitory concentration: 150 nM
The estimate for compound 4 lay 1.7-fold (0.24 log units) above the measured number, within the range that was stated.
By their numbers in this assay, from the lowest: compounds 4, 3, 2 and 1 (each within the scatter of the next, the first and the last beyond it).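

In this assay, 2-fluorophenyl in place of 3-fluorophenyl on the aromatic nitrogen stays within the scatter, a 1.5-fold lower number from compound 3 to compound 4 (0.17 log units; within the scatter), and so does 2-fluorophenyl in place of 3-hydroxyphenyl, a 1.9-fold lower number from compound 2 to compound 4 (0.27 log units; within the scatter). For the compounds shown here, only 2-fluorophenyl in place of 4-methoxyphenyl gives a step beyond the scatter, a 2.2-fold lower number from compound 1 to compound 4 (0.34 log units; beyond the scatter), a modest one but the first such step at this position. No measurement at hand bears on the reason for this step. Open, going by these compounds, is how an amine or a carboxylic acid on the phenyl ring, or a longer chain in place of that ring, would read in this assay.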